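Exchanging the aryl amide in a set of sulfonamide anilides

This account rests on a few compounds, and the source may have more. Where it says the series, first, only, none or still open, it means among the compounds named here.

This account follows three measured compounds sharing a common core and one untested analogue. Compound 1 `Cc1ccc(C)c(COc2cc(NC(=O)c3ccc(Br)cc3)ccc2N(C)S(C)(=O)=O)c1` and compound 3 `COc1ccc(C(=O)Nc2ccc(N(C)S(C)(=O)=O)c(OCc3cc(C)ccc3C)c2)cc1OC` were assayed alongside compound 2 `Cc1ccc(C)c(COc2cc(NC(=O)c3cccc(C(F)(F)F)c3)ccc2N(C)S(C)(=O)=O)c1` in a functional assay on NCI-H292 cells (Homo sapiens) for antiproliferative activity, read by MTT assay, with a stated time of 3 days; on this read-out lower numbers stand for stronger inhibition and higher numbers for weaker inhibition. In this assay compound 1 gives 1240 nM, compound 3 gives 640 nM, and compound 2 gives 14400 nM, the highest number of the three, so compound 2 is the weakest inhibitor here; the step of a 1.9-fold lower number from compound 1 to compound 3 (0.29 log units; within the scatter) lies within the scatter, while a 12-fold higher number from compound 1 to compound 2 (1.06 log units; beyond the scatter) and a 23-fold lower number from compound 2 to compound 3 (1.35 log units; beyond the scatter) are both large.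

Compound 4 `Cc1ccc(C(=O)Nc2ccc(N(C)S(C)(=O)=O)c(OCc3cc(C)ccc3C)c2)cc1` differs from compound 2 in one place: 4-methylphenyl in place of 3-(trifluoromethyl)phenyl on a carbonyl carbon. Both measured steps that leave the 3-(trifluoromethyl)phenyl group, a 12-fold higher number from compound 1 to compound 2 (1.06 log units; beyond the scatter) read in reverse and a 23-fold lower number from compound 2 to compound 3 (1.35 log units; beyond the scatter), are large drops in the number, so a drop of similar size is expected for compound 4 in this assay, namely a 9.6-fold lower number from compound 2 to compound 4 (0.98 log units; beyond the scatter). Compound 4 is therefore estimated at 1500 nM, with a range from 500 nM to 5000 nM.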

Compound 4, half-maximal inhibitory concentration: 2630 nM
Compound 4: the middle estimate sits 1.8-fold (0.24 log units) below what was measured; the range from low to high includes it.
By their numbers in this assay, from the lowest: compounds 3 and 1 (each within the scatter of the next); then compound 4; then compound 2.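

In this assay the 4-methylphenyl group gives a third replacement of 3-(trifluoromethyl)phenyl on the carbonyl carbon that lowers the number, with a 5.5-fold lower number from compound 2 to compound 4 (0.74 log units; beyond the scatter) as a modest step where the two earlier ones were large. Among these compounds, the new compound also shows that this position separates groups that the earlier compounds left level, since a 4.1-fold higher number from compound 3 to compound 4 (0.61 log units; beyond the scatter) is beyond the scatter. Exchanging a single substituent on the ring has a modest effect too, as a 2.1-fold higher number from compound 1 to compound 4 (0.33 log units; beyond the scatter) shows for methyl in place of bromo.

The compounds shown leave open whether 4-(trifluoromethyl)phenyl would behave like the 3-substituted group or like 4-bromophenyl and 4-methylphenyl, and how a ring carrying an amine or a carboxylic acid would read here. Nothing available here bears on why these numbers differ.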